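The compounds below may be only part of what the source reports. "The series", "measured", "known", "first", "only" and "open" are said of these compounds alone.

Four compounds share a core in which a dicyano-bearing pyrimidinone is joined through a sulfur-linked ketone to a methylthiazole carrying a phenyl ring. Compound 1 `COc1ccc(-c2nc(SCC(=O)c3sc(-c4ccccc4)nc3C)[nH]c(=O)c2C#N)cc1OC` carries a 3,4-dimethoxyphenyl group on the core and an unsubstituted phenyl on the thiazole. In a functional assay on U-87MG ATCC cells for antiproliferative activity against U-87 MG (Homo sapiens), read by MTT assay, with a stated time of 48 h, tested at 10 uM (a lower number here means a stronger effect, a higher number a weaker effect of the compound at the concentration tested), compound 1 gives 69.8%. Compound 2 `COc1ccc(-c2nc(SCC(=O)c3sc(-c4ccc(Cl)cc4)nc3C)[nH]c(=O)c2C#N)cc1OC` differs from compound 1 by chloro in place of hydrogen on an aromatic carbon, and in this assay compound 2 gives 83.3%, so that a number 13.5 percentage points higher from compound 1 to compound 2 (beyond the scatter). Compound 3 `Cc1nc(-c2ccccc2)sc1C(=O)CSc1nc(-c2ccc(Cl)cc2)c(C#N)c(=O)[nH]1` differs from compound 1 in the core, by 4-chlorophenyl in place of 3,4-dimethoxyphenyl on an aromatic carbon, and in this assay compound 3 gives 85.2%, so that a number 15.4 percentage points higher from compound 1 to compound 3 (beyond the scatter). The values of compound 2 and compound 3 lie within the scatter of each other, so nothing separates them.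

Compound 4 `Cc1nc(-c2ccc(Cl)cc2)sc1C(=O)CSc1nc(-c2ccc(Cl)cc2)c(C#N)c(=O)[nH]1` has not yet been measured. It differs from compound 3 by chloro in place of hydrogen on an aromatic carbon, the same change that turns compound 1 into compound 2, with the place described in the same words both times. Going by the values given here, the only guide to what this change does is the step of a number 13.5 percentage points higher from compound 1 to compound 2 (beyond the scatter), measured on a core that differs by 4-chlorophenyl in place of 3,4-dimethoxyphenyl on an aromatic carbon. On that basis a step of about a number 5.8 percentage points higher from compound 3 to compound 4 (within the scatter) is expected from compound 3 to compound 4 in this assay, somewhat smaller than the earlier one since compound 3 already sits high and the read-out cannot rise far. Compound 4 is therefore estimated to give about 91% in this assay, expected to fall between 80% and 100%.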

Compound 4, a percentage reported as activity, at one concentration (the size of the read-out at that concentration, not a potency): 98.4%
Compound 4: middle estimate off by 7.4 percentage points, on the low side; the range from low to high includes it.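

In this assay, the change from phenyl to 4-chlorophenyl gives a number 13.2 percentage points higher from compound 3 to compound 4 (beyond the scatter), and its size carries over from one core to the other: the same change on two cores in this assay, a number 13.5 percentage points higher (beyond the scatter) from compound 1 to compound 2 and a number 13.2 percentage points higher (beyond the scatter) from compound 3 to compound 4, 0.3 percentage points apart, within the scatter of two such steps. The swap of 3,4-dimethoxyphenyl for 4-chlorophenyl gives a number 15.1 percentage points higher from compound 2 to compound 4 (beyond the scatter), and it too keeps its size whichever phenyl group the compound carries at the other end: the same change on two cores in this assay, a number 15.4 percentage points higher (beyond the scatter) from compound 1 to compound 3 and a number 15.1 percentage points higher (beyond the scatter) from compound 2 to compound 4, 0.3 percentage points apart, within the scatter of two such steps. Across these four compounds the two changes therefore simply add up, each moving the number the same way, but this rests on a single square of compounds in one assay at one concentration, so it does not show that the chloro step would carry over to other cores, and it does not explain why either change has this effect.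

Compound 1 gives 69.8%, and both changes shown raise the number, which means a weaker effect, so it remains open whether any change at these two places would bring the number down from that of compound 1. Also open, on these data alone, is how other groups in the place of the chloro would behave, such as bromo, an amine or a carboxylic acid, and what happens when the nitrile or the sulfur-linked ketone of the shared core is altered.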